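Removing the aromatic methoxy from compound 2

This account rests on a few compounds, and the source may have more. Where it says the series, first, only, none or still open, it means among the compounds named here.

Of the compounds shown here, two carry numbers so far: compound 1 `CO[C@H]1C[C@H](C)Cc2cc(cc(O)c2O)NC(=O)/C(C)=C/CC[C@H](OC)[C@@H](OC(N)=O)/C(C)=C/[C@H](C)[C@H]1O` and compound 2 `COc1c(O)cc2cc1C[C@@H](C)C[C@H](OC)[C@H](O)[C@@H](C)/C=C(\C)[C@H](OC(N)=O)[C@@H](OC)CC/C=C(\C)C(=O)N2`. In a functional assay on KPL4 cells (Homo sapiens) for inhibition (a higher number here means a weaker inhibitor of growth, a lower number a stronger inhibitor of growth), compound 1 gives 4330 nM, and compound 2 gives 450 nM. Of these two, compound 2 stands lowest, its nearest neighbour being compound 1, the gap given by a 9.6-fold lower number from compound 1 to compound 2 (0.98 log units; beyond the scatter). Compound 3 `CO[C@H]1C[C@H](C)Cc2cc(O)cc(c2)NC(=O)/C(C)=C/CC[C@H](OC)[C@@H](OC(N)=O)/C(C)=C/[C@H](C)[C@H]1O` takes the change (hydrogen in place of methoxy on an aromatic carbon), on an aromatic carbon of a six-membered aromatic ring of carbon only, ortho to a hydroxy group. For the measured compounds named here, no measured step removes a methoxy group outright. Going by the values given here, the only known step, a 9.6-fold lower number from compound 1 to compound 2 (0.98 log units; beyond the scatter), concerns methyl in place of hydrogen on an oxygen on the same ring and shows that substitution here moves the number, without fixing the direction for compound 3. A modest step toward a higher number is expected for compound 3, a 3.3-fold higher number from compound 2 to compound 3 (0.52 log units; beyond the scatter). Compound 3 is estimated at 1500 nM, within 300 nM to 8000 nM.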

Compound 3, concentration for 50% growth inhibition: 730 nM
Compound 3: the middle estimate sits 2.1-fold (0.31 log units) above what was measured; low and high end bracket the measured number.
By their numbers in this assay, from the lowest: compounds 2 and 3 (each within the scatter of the next); then compound 1.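

In this assay hydrogen in place of methoxy on an aromatic carbon gives a 1.6-fold higher number from compound 2 to compound 3 (0.21 log units; within the scatter) and so does not separate the two groups at this position. Hydrogen in place of hydroxy on an aromatic carbon gives a 5.9-fold lower number from compound 1 to compound 3 (0.77 log units; beyond the scatter) and methyl in place of hydrogen on the oxygen gives a 9.6-fold lower number from compound 1 to compound 2 (0.98 log units; beyond the scatter), so among these three compounds the higher number goes with the free hydroxy group of compound 1, whether that group is removed or capped. Nothing at hand bears on the reason for these numbers.

Still open, from the compounds shown here alone, is whether an amine, a fluorine atom or a longer chain such as ethoxy at this position would stay with hydrogen and methoxy or fall with hydroxy. The compounds shown also leave open what the remaining hydroxy group on the ring contributes, since all three carry it.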